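Aryl exchange from compound 3 to compound 4

The compounds below may be only part of what the source reports. "The series", "measured", "known", "first", "only" and "open" are said of these compounds alone.

In a functional assay on EKVX cells (Homo sapiens) for inhibition, read by sulforhodamine B assay, with a stated time of 48 h (a lower number here means a stronger inhibitor of growth, a higher number a weaker inhibitor of growth), compound 1 (`O=C(Cc1csc2nc(-c3ccc(Br)cc3)cn12)N/N=C/c1ccccc1`) gives 6920 nM, compound 2 (`O=C(Cc1csc2nc(-c3ccc(Br)cc3)cn12)N/N=C/c1ccc(O)cc1`) gives 11500 nM and compound 3 (`COc1cccc(OC)c1/C=N/NC(=O)Cc1csc2nc(-c3ccc(Br)cc3)cn12`) gives 17000 nM. Two steps fix the standing of compound 3: a 2.5-fold higher number from compound 1 to compound 3 (0.39 log units; beyond the scatter) and a 1.5-fold higher number from compound 2 to compound 3 (0.17 log units; within the scatter). The remaining step is a 1.7-fold higher number from compound 1 to compound 2 (0.22 log units; within the scatter).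

Compound 4 (`O=C(Cc1csc2nc(-c3ccc(Br)cc3)cn12)N/N=C/c1ccc(Cl)cc1Cl`) carries 2,4-dichlorophenyl in place of 2,6-dimethoxyphenyl on a carbon with a double bond to nitrogen. Going by the values given here, no measured compound carries chlorine, so the measured steps bear on this change only indirectly. The largest change seen at this place, a 2.5-fold higher number from compound 1 to compound 3 (0.39 log units; beyond the scatter), is modest, and it is the one that brought in the group now leaving. A small move toward a lower number in this assay is therefore expected, but nothing beyond the scatter. The expected step is a 1.7-fold lower number from compound 3 to compound 4 (0.23 log units; within the scatter). The estimate for compound 4 is 10000 nM, with an expected range of 4500 nM to 21000 nM.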

Compound 4, concentration for 50% growth inhibition: 31600 nM
Compound 4: the middle estimate sits 3.2-fold (0.50 log units) below what was measured; measured number above the stated range.
By their numbers in this assay, from the lowest: compounds 1, 2, 3 and 4 (each within the scatter of the next, the first and the last beyond it).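

In this assay, going by these compounds alone, the 2,4-dichlorophenyl group is the first chlorine-bearing group at this place, and a 1.9-fold higher number from compound 3 to compound 4 (0.27 log units; within the scatter) does not separate it from 2,6-dimethoxyphenyl. Within the data shown here, two aryl groups with quite different substituents thus both stand apart from plain phenyl, with a 4.6-fold higher number from compound 1 to compound 4 (0.66 log units; beyond the scatter) as the largest step at this place so far, while a 2.7-fold higher number from compound 2 to compound 4 (0.44 log units; beyond the scatter) adds the first step beyond the scatter from 4-hydroxyphenyl. No available data explain why the dichloro exchange gives this result.

As far as these compounds go, it remains open whether one chlorine, as in 4-chlorophenyl, already produces the step from phenyl, or whether both chlorines are needed. Also open, from the compounds shown here alone, is whether a phenyl ring bearing a dimethylamino group or a carboxylic acid would give a number lower than that of compound 1.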